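Selenocyanate carbamates: carbamate ester variation

The compounds below may be only part of what the source reports. "The series", "measured", "known", "first", "only" and "open" are said of these compounds alone.

Measured so far:
compound 1, `CCCOC(=O)Nc1ccc([Se]C#N)cc1`: 9300 nM
compound 2, `O=C(Nc1ccc([Se][Se]c2ccc(NC(=O)OCc3ccc([N+](=O)[O-])cc3)cc2)cc1)OCc1ccc([N+](=O)[O-])cc1`: 8600 nM

In a functional assay on CCRF-CEM cells (Homo sapiens) for cytotoxicity, read by MTT assay, with a stated time of 72 h (on this read-out higher numbers stand for weaker inhibition of growth and lower numbers for stronger inhibition of growth), compound 1 gives 9300 nM, and compound 2 gives 8600 nM; the two values sit within the scatter of each other, so neither is set apart. Compound 3, `N#C[Se]c1ccc(NC(=O)Oc2ccccc2)cc1`, differs from compound 1 as follows: phenyl in place of propyl on an oxygen next to a carbonyl group. Among the measured compounds shown here, no measured pair shows what this kind of change does, so no step beyond the scatter is expected in either direction. Compound 3 is therefore estimated at 8500 nM (range 3000 nM to 25000 nM), an expected step of a 1.1-fold lower number from compound 1 to compound 3 (0.04 log units; within the scatter).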

Compound 3, concentration for 50% growth inhibition: 22900 nM
Beside the measured number, compound 3's estimate is 2.7-fold (0.43 log units) below it; the range from low to high includes it.
By their numbers in this assay, from the lowest: compounds 2 and 1 (each within the scatter of the next); then compound 3.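

In this assay the position is not indifferent to its group: phenyl in place of propyl on an oxygen next to a carbonyl group gives a 2.5-fold higher number from compound 1 to compound 3 (0.39 log units; beyond the scatter) and so moves the number beyond the scatter, though modestly. This single pair fixes the direction of the change only for these two groups. Nothing at hand accounts for the step.

Open, going by these compounds, is whether the ring itself goes with the step. A benzyl group or a longer chain on that oxygen would separate ring from chain length.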